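Amine substituent change on the shared core

The compounds below may be only part of what the source reports. "The series", "measured", "known", "first", "only" and "open" are said of these compounds alone.

In a functional assay on MCF7 cells (Homo sapiens) for inhibition, read by sulforhodamine B assay (on this read-out lower numbers stand for stronger inhibition and higher numbers for weaker inhibition), compound 1 `CCCc1ccc(NC2=CC(=O)c3c(nc4n3[C@H]3OC[C@@H](O)[C@H]3OC4)C2=O)cc1` gives only a limit, > 4000 nM. Compound 2 `O=C1C=C(NCc2ccccc2)C(=O)c2c1nc1n2[C@H]2OC[C@@H](O)[C@H]2OC1` also gives only a limit in this assay, > 8000 nM. Both values shown sit at limits, as the limit of > 4000 nM in this assay, at which 1 of the 2 values shown sits, and the limit of > 8000 nM in this assay, at which 1 of the 2 values shown sits, record, so compound 2 stands at a limit with no number attached. Compound 3 `O=C1C=C(NC2CCCCC2)C(=O)c2c1nc1n2[C@H]2OC[C@@H](O)[C@H]2OC1` differs from compound 2 by cyclohexyl in place of benzyl on an amine nitrogen. Among the measured compounds shown here, no measured step between two compounds exists. In this assay no step beyond the scatter is expected, a step that the limit leaves unreadable from compound 2 to compound 3. Compound 3 is expected to give 10000 nM, estimated between 3000 nM and 40000 nM.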

Compound 3, half-maximal inhibitory concentration: > 8000 nM
Compound 3: only a limit was reported; the forecaster's own chance of this, stated with the estimate: 80%; the middle value lies beyond the limit too.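

In this assay no step can be read between compound 2 and compound 3, as both stand at the same limit: the limit of > 8000 nM in this assay, at which 2 of the 3 values shown sit.

The compounds shown leave open how strongly compound 2 and compound 3 inhibit, and whether cyclohexyl and benzyl on the amine nitrogen differ at all.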